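Swapping 2,5-dimethylphenyl for 3,5-dibromophenyl on the carbonyl

The source may report more compounds than this note shows. Statements on the series, on what has been measured and on what is new or still open speak of the compounds shown alone.

Among the compounds with values here, in a functional assay on C8166 cells (Homo sapiens) for cytotoxicity, read by MTT assay (on this read-out lower numbers stand for higher toxicity in this test and higher numbers for lower toxicity in this test), compound 1 `Cc1ccc(C)c(C(=O)Nc2cc(Cl)ccc2OCC(=O)Nc2ccc(S(N)(=O)=O)cc2C)c1` gives 79700 nM as one of only two numbers so far. The other comes from compound 2 `Cc1cc(S(N)(=O)=O)ccc1NC(=O)COc1ccc(Cl)cc1NC(=O)c1ccc(Cl)c(Cl)c1` at 158000 nM and lies within the scatter of it. Compound 3 `Cc1cc(S(N)(=O)=O)ccc1NC(=O)COc1ccc(Cl)cc1NC(=O)c1cc(Br)cc(Br)c1` has not been measured and differs from compound 1 in one place. The change is 3,5-dibromophenyl in place of 2,5-dimethylphenyl on a carbonyl carbon and amounts to 3,5-dibromophenyl in place of 2,5-dimethylphenyl on a carbonyl carbon. Within the data shown here, the one measured step at that place, 3,4-dichlorophenyl in place of 2,5-dimethylphenyl, is a 2.0-fold higher number from compound 1 to compound 2 (0.30 log units; within the scatter) and this alone suggests no step beyond the scatter in this assay for compound 3. Among the measured compounds shown here, no bromine-bearing compound has yet been measured. The estimated step is a 1.4-fold higher number from compound 1 to compound 3 (0.14 log units; within the scatter) and any drift is expected to be upward. For compound 3 the estimated value is 110000 nM with an expected range from 40000 nM to 300000 nM in this test.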

Compound 3, half-maximal cytotoxic concentration: 89700 nM
Estimate against measurement, compound 3: 1.2-fold (0.09 log units) above, and the stated range covers the measured number.
By their numbers in this assay, from the lowest: compounds 1, 3 and 2 (each within the scatter of the next).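

In this assay the 3,5-dibromophenyl group on the carbonyl carbon stays within the scatter of both groups measured there: in place of 2,5-dimethylphenyl it gives a 1.1-fold higher number from compound 1 to compound 3 (0.05 log units; within the scatter) and in place of 3,4-dichlorophenyl it gives a 1.8-fold lower number from compound 2 to compound 3 (0.25 log units; within the scatter) in this test. Within the data shown here, the single step known before now has company, and the three aromatic groups, bearing methyl, chlorine or bromine, give numbers that cannot be told apart at this place. No measurement at hand accounts for this result.

On these data alone, all three compounds carry a six-membered aromatic ring of carbon only on this carbonyl, so it remains open whether an amine, a carboxylic acid or a longer chain there would move the number beyond the scatter. As far as these compounds go, only this one place varies among them, and the rest of the shared core remains untested.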